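Trading a Ring for an Isobutyl Group

This account rests on a few compounds, and the source may have more. Where it says the series, first, only, none or still open, it means among the compounds named here.

In a functional assay on HUVEC cells (Homo sapiens) for antiproliferative activity, read by WST assay, with a stated time of 5 days (on this read-out lower numbers stand for stronger inhibition and higher numbers for weaker inhibition), compound 1 (`Cc1cc(C(=O)Nc2cc(Oc3ccc4nc(NC(=O)C5CC5)cn4c3)ccc2C)n(C)n1`) measures 0.8 nM and is the stronger inhibitor of the pair. Compound 2 (`Cc1nc(C(=O)Nc2cc(Oc3ccc4nc(NC(=O)C5CC5)nn4c3)ccc2C)c(C)s1`) measures 4.3 nM and holds the higher number, a gap beyond the usual scatter. Compound 3 (`Cc1ccc(Oc2ccc3nc(NC(=O)C4CC4)nn3c2)cc1NC(=O)CC(C)C`) differs from compound 2 in one place (isobutyl in place of 2,5-dimethyl-1,3-thiazol-4-yl on a carbonyl carbon) with isobutyl in place of 2,5-dimethyl-1,3-thiazol-4-yl on a carbonyl carbon. Among the measured compounds shown here, no measured pair shows this change, so what follows is only an expectation. In this assay a weakening is expected, an estimated 12-fold higher number from compound 2 to compound 3 (1.07 log units; beyond the scatter) towards a higher number. The estimated value for compound 3 is 50 nM (expected range 8 nM to 300 nM).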

Compound 3, half-maximal inhibitory concentration in the HUVEC assay: 56 nM
For compound 3 the middle estimate is 1.1-fold (0.05 log units) below the measured one, within the range that was stated.
By their numbers in the HUVEC assay, from the lowest: compound 1; then compound 2; then compound 3.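

Compounds 1 and 2 differ in more than one place, so they could not isolate this position. Here a single change on the carbonyl carbon matters strongly in the HUVEC assay, where isobutyl in place of 2,5-dimethyl-1,3-thiazol-4-yl gives a 13-fold higher number from compound 2 to compound 3 (1.11 log units; beyond the scatter). The same change moves a physicochemical assay for solubility, measured as kinetic solubility, at pH 6.8 (a higher number here means a more soluble compound, a lower number a less soluble compound), in the favourable direction, so potency is lost while solubility is gained: the measured solubility of compound 2, 0.16 ug/mL, and of compound 3, 12 ug/mL, a 75-fold higher number (1.88 log units; beyond the scatter) In the physicochemical assay compound 2 gives 0.16 ug/mL and compound 3 gives 12 ug/mL.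

Still open, from the compounds shown here alone, is whether another group on this carbonyl carbon, such as a phenyl ring or a chain ending in an amine, could keep both the potency and the solubility.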